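The source may hold more compounds than are shown below. What is called first, only, known or untested is meant among the compounds shown, and "the series" means these compounds.

Of the compounds shown here, two have been measured in an ADME assay on microsomes from liver (Mus musculus), read by LC-MS, using NADPH, with a stated time of 30 min, tested at 1 uM; on this read-out lower numbers stand for a less stable compound and higher numbers for a more stable compound. Compound 1 `C[C@H](Nc1nc(N)nc(N)c1C#N)c1c(-c2ccccc2)c(=O)n2cc(F)ccc2c1-c1ccc(F)cc1` carries a 4-fluorophenyl group on its core, and in this assay compound 1 gives 83%. Compound 2 `Cc1nc(N)nc(N[C@@H](C)c2c(-c3ccccc3)c(=O)n3cc(F)ccc3c2C)c1C#N` carries a methyl group at the same place and a further methyl on its aminopyrimidine, and in this assay compound 2 gives 75%. On these two numbers compound 2 stands alongside compound 1, the gap between them lying within the usual scatter of this kind of measurement, so the two compounds cannot be told apart on this read-out.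

Compound 3 `Cc1nc(N)nc(N[C@@H](C)c2c(-c3ccccc3)c(=O)n3cc(F)ccc3c2-c2ccc(F)cc2)c1C#N` has not yet been measured. It differs from compound 2 in one place: 4-fluorophenyl in place of methyl on an aromatic carbon. For the measured compounds named here, nothing in the measured pairs isolates this change, so no step can be quoted for it. Going by the values given here, the only guide is that both measured compounds, one with each of these two groups at that position, remain largely intact in this assay.

On that basis compound 3 is expected to give about 78% in this assay, with a range from 62% to 90%. The step of a number 3 percentage points higher from compound 2 to compound 3 (within the scatter) is thus expected to stay within the scatter, with no clear direction.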

Compound 3, percent of the compound remaining: 65%
Compound 3: middle estimate off by 13 percentage points, on the high side, within the range that was stated.
By their numbers in this assay, from the lowest: compounds 3, 2 and 1 (each within the scatter of the next, the first and the last beyond it).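

For the compounds shown here, compound 3 supplies the first pair in which 4-fluorophenyl and methyl can be compared at this position of the shared core with everything else held the same. In this assay this change gives a number 10 percentage points lower from compound 2 to compound 3 (within the scatter) so the larger group with its added aromatic ring cannot be told apart from methyl here on this read-out. Going by these compounds alone, compound 3 also isolates the other place in which compounds 1 and 2 differed: with 4-fluorophenyl kept on the core, methyl in place of amino on an aromatic carbon gives a number 18 percentage points lower from compound 1 to compound 3 (beyond the scatter) and this is the only one of the two steps that reaches beyond the scatter. No measurement at hand offers an explanation for either step.

The compounds shown leave open whether methyl in place of amino would give a similar step with methyl rather than 4-fluorophenyl on the core. They also leave open how a cyclopropyl group or a morpholine at the 4-fluorophenyl position would read in this assay and whether a chlorine or a methoxy group on the aminopyrimidine in place of the methyl would stand nearer to compound 1 or compound 3.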